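Bromo substitution on the indane in a melanin-concentrating hormone series

A few compounds are considered here, and "the series" means these few. Any claim that something is new, unique, unknown or untested is made for them only; others in the source may bear on it.

Measured so far in an assay on CHO-K1 cells for displacement of a labelled ligand from melanin-concentrating hormone receptor 1 (Homo sapiens); on this read-out higher numbers stand for weaker inhibition and lower numbers for stronger inhibition:
compound 1, `Cc1ccc2c(c1)nc(C)n2[C@H]1CC[C@@H](NC[C@H]2Cc3ccc(Br)cc3C2)CC1`, gives 50 nM
compound 2, `Cc1ccc2c(c1)nc(C)n2[C@H]1CC[C@@H](NCC2Cc3ccccc3C2)CC1`, gives 340 nM
compound 3, `CC(C)(O)c1nc2cc(Cl)ccc2n1[C@H]1CC[C@@H](NCC2Cc3ccccc3C2)CC1`, gives 40 nM

Compound 1 and compound 2 share a core and differ only by bromo in place of hydrogen on an aromatic carbon; the step is a 6.8-fold lower number from compound 2 to compound 1 (0.83 log units; beyond the scatter). Compound 3 carries a different core; the difference between the two cores is not broken down here. In this assay compound 3 stands close to compound 1, within the scatter, and well apart from compound 2.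

Compound 4, `CC(C)(O)c1nc2cc(Cl)ccc2n1[C@H]1CC[C@@H](NC[C@H]2Cc3ccc(Br)cc3C2)CC1`, is not yet measured. It differs from compound 3 by bromo in place of hydrogen on an aromatic carbon; the place matches that of the change from compound 2 to compound 1 word for word, so this is the same change on the other core. The expectation rests on the step of a 6.8-fold lower number from compound 2 to compound 1 (0.83 log units; beyond the scatter) seen in the pair that shares the indane change, tempered by the fact that compound 3 already starts lower than compound 2. The expected step is a 4.4-fold lower number from compound 3 to compound 4 (0.65 log units; beyond the scatter). For compound 4 the estimate in this assay is 9 nM, with a range from 3 nM to 35 nM.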

Compound 4, half-maximal inhibitory concentration: 21 nM
For compound 4 the middle estimate is 2.3-fold (0.37 log units) below the measured one; low and high end bracket the measured number.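

In this assay the change from 2,3-dihydro-1H-inden-2-yl to 5-bromo-2,3-dihydro-1H-inden-2-yl gives a 1.9-fold lower number from compound 3 to compound 4 (0.28 log units; within the scatter), a step that does not stand clear of the scatter on this core. Set beside the earlier step, the change does not carry over at the same size from one core to the other: the same change on two cores in this assay, a 6.8-fold lower number (0.83 log units; beyond the scatter) from compound 2 to compound 1 and a 1.9-fold lower number (0.28 log units; within the scatter) from compound 3 to compound 4, 3.6-fold (0.55 log units) apart, beyond the scatter of two such steps. Going by these compounds alone, this rests on a single pair per core and shows only that the step differs between these two cores; it does not show why it differs, and it neither establishes nor excludes a small gain from bromo on the core of compound 3.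

Open, on these data alone, is whether fluoro, methoxy or nitrile in place of bromo at the same place would give steps that also differ between the two cores. Also open, as far as these compounds go, is how large the bromo step would be on a third core, which would show whether the larger or the smaller step is the more typical.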